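Back from Isopropyl to an Aromatic Ring

The source may report more compounds than this note shows. Statements on the series, on what has been measured and on what is new or still open speak of the compounds shown alone.

In a functional assay on KB-V1 cells (Homo sapiens) for cytotoxicity, read by MTT assay, with a stated time of 72 h (on this read-out lower numbers stand for stronger inhibition and higher numbers for weaker inhibition), compound 2 `CC(C)NC(=S)N/N=C1\C(=O)Nc2ccccc21` gives 10300 nM and holds the higher of two numbers, while compound 1 `O=C1Nc2ccccc2/C1=N/NC(=S)Nc1ccccc1` gives 1470 nM on the same scale. Compound 3 `O=C1Nc2ccccc2/C1=N/NC(=S)Nc1cccc(Cl)c1` carries 3-chlorophenyl in place of isopropyl on an amide-type nitrogen. Going by the values given here, the one measured step that bears on this is a 7.0-fold higher number from compound 1 to compound 2 (0.85 log units; beyond the scatter) for the opposite kind of swap, from phenyl to isopropyl. Among the compounds with values here, no measured compound carries the chlorine, so a reversal of similar size is expected in this assay toward lower numbers. The estimated change is a 10-fold lower number from compound 2 to compound 3 (1.01 log units; beyond the scatter) overall. The expected value for compound 3 is 1000 nM (range 350 nM to 3000 nM).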

Compound 3, half-maximal inhibitory concentration: 640 nM
The estimate for compound 3 lay 1.6-fold (0.19 log units) above the measured number, within the range that was stated.
By their numbers in this assay, from the lowest: compound 3; then compound 1; then compound 2.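

In this assay, an aromatic ring on this amide-type nitrogen does more than win back what isopropyl lost, giving a 16-fold lower number from compound 2 to compound 3 (1.21 log units; beyond the scatter). The ring is not the whole story, since adding the chlorine to the phenyl ring gives a 2.3-fold lower number from compound 1 to compound 3 (0.36 log units; beyond the scatter), so a substituent on the ring also moves the number. Nothing at hand explains either change. Chloro is the only substituent on the ring among these compounds, so it remains open whether a methyl, a methoxy or an amine in its place would lower the number as well.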